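This account rests on a few compounds, and the source may have more. Where it says the series, first, only, none or still open, it means among the compounds named here.

Of the compounds shown here, two of one shared core have been measured so far. Compound 1 `CC(=O)N(C(C)=O)c1c(C#N)[n+]([O-])c2cc(Cl)ccc2[n+]1[O-]` and compound 2 `COc1ccc2c(c1)[n+]([O-])c(C(=O)N=[N+]=[N-])c(C)[n+]2[O-]` were both tested in a functional assay on Ehrlich cells (Mus musculus) for cytotoxicity, read by trypan blue exclusion, with a stated time of 2 h, tested at 50 ug/mL; on this read-out lower numbers stand for a stronger effect and higher numbers for a weaker effect at the one concentration tested. In this assay compound 1 gives 78.9%, and in this assay compound 2 gives 77.9%. Compound 2 has the lower of the two numbers, but its nearest neighbour is compound 1, whose value sits only slightly higher, so the two values lie within the usual scatter of each other and neither compound can be called the stronger.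

Compound 3 `COc1ccc2c(c1)[n+]([O-])c(NC(=O)OC(C)C)c(C)[n+]2[O-]` has not yet been measured. It differs from compound 2 in one place: a group of 7 heavy atoms (4 carbon, 1 nitrogen, 2 oxygen; no ring) in place of a group of 5 heavy atoms (1 carbon, 3 nitrogen, 1 oxygen; no ring), on an aromatic carbon The group that enters is the (isopropoxycarbonyl)amino group, the group that leaves has no common name.

Within the data shown here, no step between two measured compounds is known here, so there is nothing to set the size of this change against. Given that both measured compounds sit close together in this assay, the step from compound 2 to compound 3 is expected to be small, a number 2.1 percentage points higher from compound 2 to compound 3 (within the scatter), and not clearly beyond the scatter in either direction. Compound 3 is therefore estimated to give about 80% in this assay, within a range from 65% to 95%.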

Compound 3, a percentage reported as activity, at one concentration (the size of the read-out at that concentration, not a potency): 92.6%
Estimate against measurement, compound 3: 12.6 percentage points below; the measured number falls inside the stated range.
By their numbers in this assay, from the lowest: compounds 2 and 1 (each within the scatter of the next); then compound 3.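

In this assay, among these compounds, this change is the first step that can be read, and it is a number 14.7 percentage points higher from compound 2 to compound 3 (beyond the scatter), so the (isopropoxycarbonyl)amino group gives a weaker effect at the one concentration tested than the group it replaces. The result shows that this aromatic carbon, next to the ring nitrogen and ortho to a methyl group, is not indifferent to what it carries, which the two earlier compounds could not show because they differ in more than one place. The swap alters several things at once, since the entering group has more heavy atoms, fewer double bonds outside the aromatic rings and a hydrogen-bond donor that the leaving group lacks, and no available information shows which of these differences matters.

The compounds shown leave open whether a plain amino group or an acetylamino group at this carbon would sit closer to compound 2 or to compound 3, and whether a longer chain in place of the isopropyl group would move the number further. They also leave open whether the same exchange would have a similar effect on the core of compound 1.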